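Side-chain methyl step on the shared core

The source may hold more compounds than are shown below. What is called first, only, known or untested is meant among the compounds shown, and "the series" means these compounds.

Measured so far:
compound 1 `CCNc1cc(Oc2ccc(NC(=O)Nc3cccc(C(F)(F)F)c3)cc2)ncn1`, 25 nM 
compound 2 `CNc1cc(Oc2ccc(NC(=O)Nc3cccc(C(F)(F)F)c3)cc2)ncn1`, 40 nM 
compound 3 `O=C(Nc1ccc(Oc2cc(NCCO)ncn2)cc1)Nc1cccc(C(F)(F)F)c1`, 32 nM 

In an assay on isolated protein for inhibition of serine/threonine-protein kinase TNNI3K (Homo sapiens) (a lower number here means a stronger inhibitor, a higher number a weaker inhibitor), compound 1 gives 25 nM, compound 2 gives 40 nM and compound 3 gives 32 nM. The step of a 1.6-fold lower number from compound 2 to compound 1 (0.20 log units; within the scatter) comes with methyl in place of hydrogen on a saturated chain carbon bound to a nitrogen on an aromatic ring. Compound 3 differs from compound 2 by hydroxymethyl in place of hydrogen on a saturated chain carbon bound to a nitrogen on an aromatic ring, with the step of a 1.3-fold lower number from compound 2 to compound 3 (0.10 log units; within the scatter); between compound 1 and compound 3 the step is a 1.3-fold higher number from compound 1 to compound 3 (0.11 log units; within the scatter).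

Compound 4 `C[C@H](O)CNc1cc(Oc2ccc(NC(=O)Nc3cccc(C(F)(F)F)c3)cc2)ncn1` is not yet measured. It differs from compound 3 by methyl in place of hydrogen on a saturated chain carbon bound to an oxygen on a saturated carbon and a saturated chain carbon. This is the same kind of change as that between compound 2 and compound 1, but not the same: there the place is on a saturated chain carbon bound to a nitrogen on an aromatic ring, here it is on a saturated chain carbon bound to an oxygen on a saturated carbon and a saturated chain carbon. For the measured compounds named here, the expected step of a 1.3-fold lower number from compound 3 to compound 4 (0.11 log units; within the scatter) is set beside a 1.6-fold lower number from compound 2 to compound 1 (0.20 log units; within the scatter), the only earlier step of this kind, and is taken to match it in size. Compound 4 is therefore estimated at 25 nM, expected between 10 nM and 60 nM.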

Compound 4, half-maximal inhibitory concentration: 32 nM
For compound 4 the middle estimate is 1.3-fold (0.11 log units) below the measured one; low and high end bracket the measured number.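

In this assay, methyl in place of hydrogen gives steps on the two cores that do not differ: the same change on two cores in this assay, a 1.6-fold lower number (0.20 log units; within the scatter) from compound 2 to compound 1 and no change at the digits printed (within the scatter) from compound 3 to compound 4, 1.6-fold (0.20 log units) apart, within the scatter of two such steps

The step of no change at the digits printed from compound 3 to compound 4 (within the scatter) stays within the scatter, as do a 1.3-fold lower number from compound 2 to compound 4 (0.10 log units; within the scatter) and a 1.3-fold higher number from compound 1 to compound 4 (0.11 log units; within the scatter), so all four compounds read alike in this assay. For the compounds shown here, this shows that the change is tolerated on both cores, but with every step inside the scatter and only two cores compared, it does not show that a step of any set size carries from one core to another.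

Going by these compounds, whether an amine, a carboxylic acid or a longer chain at this end of the side chain would give a step beyond the scatter stays open. So does whether the methyl change behaves alike on cores beyond these two.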